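This account rests on a few compounds, and the source may have more. Where it says the series, first, only, none or still open, it means among the compounds named here.

Measured so far in a functional assay on HCT-116 cells (Homo sapiens) for antiproliferative activity, read by MTT assay, with a stated time of 72 h; a lower number here means a stronger inhibitor, a higher number a weaker inhibitor:
- compound 1 `NC1=NC2(CCOCC2)N(OCCCOc2ccccc2)C(N)=N1`: 6010 nM
- compound 2 `NC1=NC2(CCSCC2)N(OCCCOc2ccc(Br)cc2)C(N)=N1`: 20 nM
- compound 3 `NC1=NC2(CCOCC2)N(OCCCOc2ccccc2Cl)C(N)=N1`: 70 nM

Compound 3 holds the middle number of the three, with compound 2 lower and compound 1 higher. The next step leads to compound 4 `NC1=NC2(CCOCC2)N(OCCCOc2ccc(Cl)c(Cl)c2)C(N)=N1`, with 3,4-dichlorophenyl in place of 2-chlorophenyl on an oxygen on a saturated carbon.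

Among the compounds with values here, only one measured step bears on this change, and it is large: an 86-fold lower number from compound 1 to compound 3 (1.93 log units; beyond the scatter), with chloro in place of hydrogen on an aromatic carbon. That step starts from a compound with no chloro, whereas compound 3 and compound 4 both carry it, so its size should not carry over. Within the data shown here, compound 2 differs from compound 3 in more than one place and gives no clean step. No effect of a second chloro has been measured. In this assay, a modest shift to a lower number is expected, not clearly beyond the scatter.

The expected step is a 1.6-fold lower number from compound 3 to compound 4 (0.19 log units; within the scatter).

For compound 4 the estimated value is 45 nM, with an expected range of 12 nM to 170 nM.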

Compound 4, half-maximal inhibitory concentration: 90 nM
Compound 4: the middle estimate sits 2.0-fold (0.30 log units) below what was measured; the measured number falls inside the stated range.
By their numbers in this assay, from the lowest: compound 2; then compounds 3 and 4 (each within the scatter of the next); then compound 1.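

In this assay the change to 3,4-dichlorophenyl from 2-chlorophenyl gives a 1.3-fold higher number from compound 3 to compound 4 (0.11 log units; within the scatter) so, on an oxygen on a saturated carbon, these two groups are not told apart. Measured against the phenyl of compound 1, 3,4-dichlorophenyl gives a 67-fold lower number from compound 1 to compound 4 (1.82 log units; beyond the scatter) and this large step stands alongside an 86-fold lower number from compound 1 to compound 3 (1.93 log units; beyond the scatter) which shows that it is not confined to a single chlorinated phenyl group among those tested. No measured evidence bears on the reason for this result.

Open, from the compounds shown here alone, is whether the large step depends on chloro at all, a question that a methoxy or an amine on the phenyl group could address. Also open, going by these compounds, is whether 3,4-dichlorophenyl would give a similar number on the core of compound 2.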